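Replacing acetyl in compound 2 with (4-methylphenyl)sulfonyl

The source may hold more compounds than are shown below. What is called first, only, known or untested is meant among the compounds shown, and "the series" means these compounds.

Compound 1 (`O=C(CCC1=CCCN(Cc2ccc(F)cc2)C1=O)NO`) and compound 2 (`CC(=O)Nc1ccc(CN2CCC=C(CCC(=O)NO)C2=O)cc1`) share a core. In a functional assay on HCT-15 cells (Homo sapiens) for inhibition, read by sulforhodamine B assay (a higher number here means a weaker inhibitor of growth, a lower number a stronger inhibitor of growth), compound 1 gives 9960 nM as its measured value. Compound 2 has no number to work from, since its entry reads "not determined" (no result reported) and it cannot be ranked against compound 1.

Compound 3 (`Cc1ccc(S(=O)(=O)Nc2ccc(CN3CCC=C(CCC(=O)NO)C3=O)cc2)cc1`) keeps the core of compound 2 and changes one place, with (4-methylphenyl)sulfonyl in place of acetyl on a nitrogen on an aromatic ring. The swap brings in one six-membered aromatic ring of carbon only. Among the compounds with values here, no measured pair shows what such a swap does in this assay so the expected step is a cautious guess. A modest move toward stronger growth inhibition is expected, only somewhat beyond the usual scatter, and a step too small to stand out would be no surprise.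

Within the data shown here, the only measured anchor is compound 1 at 9960 nM and the estimate leans on that single value. Compound 3 is expected at 4000 nM within an estimated range of 1200 nM to 13000 nM in this test.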

Compound 3, concentration for 50% growth inhibition: > 10000 nM
Compound 3 ended at the assay's limit (the forecaster's own chance of this, stated with the estimate: 10%); middle value at least 2.5-fold (0.39 log units) away from the limit.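

In this assay, compound 3 reads > 10000 nM, which is a limit of the assay and not a number. Within the data shown here, compound 2 has no reported result, and no step between compound 2 and compound 3 can be read. Going by these compounds, the effect on growth inhibition of placing (4-methylphenyl)sulfonyl where acetyl stood remains open.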